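Fatty acid receptor agonists: alkoxy extension on the distal ring

The source may report more compounds than this note shows. Statements on the series, on what has been measured and on what is new or still open speak of the compounds shown alone.

Measured so far:
compound 1 `O=C(O)COc1ccc(NCc2cccc(-c3ccccc3)c2)cc1F` 58.5 nM
compound 2 `Cc1ccccc1-c1cccc(CNc2ccc(OCC(=O)O)c(F)c2)c1` 4.8 nM

In a functional assay on CHO cells for agonist activity at Free fatty acid receptor 1 (Homo sapiens), read by FLIPR and calcium flux (a higher number here means that more compound is needed for the effect, a lower number that less compound is needed), compound 2 gives the lower of the two numbers; its nearest neighbour, compound 1, gives 58.5 nM. Going by the values given here, the single step between them, a 12-fold lower number from compound 1 to compound 2 (1.09 log units; beyond the scatter), concerns methyl in place of hydrogen on an aromatic carbon.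

Compound 3 `COCCOc1ccc(-c2cccc(CNc3ccc(OCC(=O)O)c(F)c3)c2)c(C)c1` has not been measured. It differs from compound 2 by 2-methoxyethoxy in place of hydrogen on an aromatic carbon. Among the compounds with values here, no measured step concerns a change of this kind; the only step available, from compound 1 to compound 2, touches a different group on the same ring and says nothing direct about an alkoxy chain there. Without a precedent, the expectation for compound 3 is a small step in this assay, possibly none beyond the scatter, written as a 1.3-fold higher number from compound 2 to compound 3 (0.10 log units; within the scatter). The estimate for compound 3 is therefore 6 nM, with a range from 1.5 nM to 20 nM.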

Compound 3, half-maximal effective concentration: 41.9 nM
The estimate for compound 3 lay 7.0-fold (0.84 log units) below the measured number; measured number above the stated range.
By their numbers in this assay, from the lowest: compound 2; then compounds 3 and 1 (each within the scatter of the next).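

In this assay, adding 2-methoxyethoxy in place of hydrogen on an aromatic carbon, meta to a methyl group and para to a large group, gives an 8.7-fold higher number from compound 2 to compound 3 (0.94 log units; beyond the scatter). Going by these compounds alone, this is the first reading at this carbon, and it shows that the distal ring can also move the number upward, whereas the only earlier change on that ring gave a 12-fold lower number from compound 1 to compound 2 (1.09 log units; beyond the scatter). Nothing available explains the rise in the number for compound 3.

A single substituent cannot separate the effect of this carbon from that of this particular chain. From the compounds shown here alone, a methoxy group, a hydroxyl group, a longer chain ending in an amine or a chain ending in a carboxylic acid at the same carbon remain open, as does the same chain without the methyl group.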